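Solubility notes on the quinolinyl-azetidine series: compound 3

The source may hold more compounds than are shown below. What is called first, only, known or untested is meant among the compounds shown, and "the series" means these compounds.

Two compounds of the series carry measured numbers in a physicochemical assay for solubility, in phosphate buffer, at pH 7.4; on this read-out higher numbers stand for higher solubility and lower numbers for lower solubility. Compound 1 `OCC1CCN(c2cccnc2OC2CN(c3ccc4ccccc4n3)C2)CC1` gives 189000 nM in this assay. Compound 2 `CN(C)C1CCN(c2nccnc2OC2CN(c3ccc4ccccc4n3)C2)CC1` gives 500000 nM in this assay, the higher of the two numbers, with compound 1 sitting a gap beyond the scatter below it. Compound 3 `Cc1ncccc1-c1nccnc1OC1CN(c2ccc3ccccc3n2)C1` differs from compound 2 in one place: 2-methylpyridin-3-yl in place of 4-(dimethylamino)piperidin-1-yl on an aromatic carbon. Among the compounds with values here, no step between measured compounds covers this change. The expected step of a 25-fold lower number from compound 2 to compound 3 (1.40 log units; beyond the scatter) is a marked fall, beyond the scatter, for compound 3. Compound 3 is thus estimated at 20000 nM in this assay, within a range of 4000 nM to 90000 nM.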

Compound 3, solubility: 253000 nM
Estimate against measurement, compound 3: 13-fold (1.10 log units) below, outside the stated range (above it).
By their numbers in this assay, from the lowest: compounds 1, 3 and 2 (each within the scatter of the next, the first and the last beyond it).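

On the aromatic carbon next to the ring nitrogen, 2-methylpyridin-3-yl in place of 4-(dimethylamino)piperidin-1-yl gives a 2.0-fold lower number from compound 2 to compound 3 (0.30 log units; within the scatter) in this assay on this change. Within the data shown here, at this position, an aromatic ring in place of a non-aromatic ring therefore leaves the read-out within the scatter, something the earlier compounds, joined by no step, could not show. Nothing at hand on this series accounts for the result.

Open, from the compounds shown here alone, is whether a carboxylic acid or a primary amine on this carbon would stay within the scatter of compound 2. Also open, going by these compounds, is what the methyl of the 2-methylpyridin-3-yl group contributes.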